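A few compounds are considered here, and "the series" means these few. Any claim that something is new, unique, unknown or untested is made for them only; others in the source may bear on it.

Measured in an ADME assay on Caco-2 cells (Homo sapiens) for permeability, in the apical to basolateral direction, at pH 7.4; on this read-out higher numbers stand for higher permeability and lower numbers for lower permeability:
- compound 1 `Cc1ccc2[nH]c(C(=O)N[C@H]3CN(S(=O)(=O)c4ccccc4)C[C@@H]3C(=O)NC[C@H]3CCCN3C)cc2c1`: 0.08 10^-6 cm/s
- compound 2 `Cc1ccc2[nH]c(C(=O)N[C@H]3CN(S(=O)(=O)c4ccccc4)C[C@@H]3C(=O)N[C@@H]3CCCN(C)C3)cc2c1`: 0.76 10^-6 cm/s
- compound 3 `Cc1ccc2[nH]c(C(=O)N[C@H]3CN(S(=O)(=O)c4ccccc4)C[C@@H]3C(=O)N[C@H]3CCCN(C)C3)cc2c1`: 0.3 10^-6 cm/s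

Of these three, compound 2 has the highest number in this assay, at 0.76 10^-6 cm/s. The next compound to consider, compound 4 `Cc1ccc2[nH]c(C(=O)N[C@H]3CN(S(=O)(=O)c4ccccc4)C[C@@H]3C(=O)N[C@@H]3CCCNC3)cc2c1`, has not been measured yet. Its difference from compound 2 is small: hydrogen in place of methyl on an amine nitrogen in a ring. Put simply, this is hydrogen in place of methyl on an amine nitrogen in a ring, so 1-methylpiperidin-3-yl becomes piperidin-3-yl.

Going by the values given here, no measured step makes this exact change, so the closest guide is what happened when the same side chain was altered in other ways. Replacing that side chain gave a 9.5-fold higher number from compound 1 to compound 2 (0.98 log units; beyond the scatter) and also a 3.8-fold higher number from compound 1 to compound 3 (0.57 log units; beyond the scatter). A subtler alteration still gave a 2.5-fold lower number from compound 2 to compound 3 (0.40 log units; beyond the scatter), because of the fact that compounds 2 and 3 differ only in the configuration as drawn. All three steps are modest but beyond the scatter, so this side chain does influence the read-out, and a step of similar size is a reasonable expectation.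

Compound 2 already holds the top value of 0.76 10^-6 cm/s, so a fall looks likelier than a rise, although no measurement tests that direction. The expected change is a 2.5-fold lower number from compound 2 to compound 4 (0.40 log units; beyond the scatter). For compound 4 the estimated value is 0.3 10^-6 cm/s, with an expected range of 0.1 10^-6 cm/s to 0.8 10^-6 cm/s.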

Compound 4, apparent permeability: 0.04 10^-6 cm/s
Compound 4: middle estimate off by 7.5-fold (0.88 log units), on the high side; measured number outside the range, below it.
By their numbers in this assay, from the lowest: compounds 4 and 1 (each within the scatter of the next); then compound 3; then compound 2.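

Going by these compounds alone, the methyl on the ring nitrogen matters more than any earlier change to this side chain: with hydrogen in its place, this assay shows a 19-fold lower number from compound 2 to compound 4 (1.28 log units; beyond the scatter) in the only step of this set printed as large. The other 1-methylpiperidin-3-yl compound also stands clearly apart from the piperidin-3-yl compound, with a 7.5-fold lower number from compound 3 to compound 4 (0.88 log units; beyond the scatter) on a comparison that also includes a change of configuration. Against the (1-methylpyrrolidin-2-yl)methyl side chain the result is a 2.0-fold lower number from compound 1 to compound 4 (0.30 log units; within the scatter) and so, without its methyl, the piperidine side chain keeps none of the advantage that 1-methylpiperidin-3-yl held over that side chain.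

From the compounds shown here alone, it remains open whether a larger group on this nitrogen, such as ethyl or acetyl, would hold, raise or lower the number, and whether the piperidin-3-yl side chain of the opposite configuration would behave like compound 4. The data shown offer no explanation for why this single change has so large an effect on the read-out.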